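Working notes: benzoyl to propanoyl on the amide-type nitrogen

The source may report more compounds than this note shows. Statements on the series, on what has been measured and on what is new or still open speak of the compounds shown alone.

Measured so far:
- compound 1 `CC1=NN(C(=O)CCc2ccccc2)C(c2cc(Br)ccc2O)C1`: 17900 nM
- compound 2 `C=CCN(CC=C)CC(=O)N1N=C(C)CC1c1cc(Br)ccc1O`: 7870 nM
- compound 3 `O=C(c1ccccc1)N1N=C(c2cc3ccccc3oc2=O)CC1c1ccccc1`: 36600 nM

All three compounds were read in a functional assay on HepG2 cells (Homo sapiens) for cytotoxicity, read by MTT assay, with a stated time of 48 h; a higher number here means a weaker inhibitor, a lower number a stronger inhibitor. Compound 3 gives the highest of the three numbers; compound 1 sits nearest to it, compound 2 furthest. Within the data shown here, the one single-point step available is a 2.3-fold lower number from compound 1 to compound 2 (0.36 log units; beyond the scatter), a change on the chain that hangs from the amide carbonyl, and it was modest.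

Compound 4 `CCC(=O)N1N=C(c2cc3ccccc3oc2=O)CC1c1ccccc1` is not yet measured. Relative to compound 3 the change is ethyl in place of phenyl on a carbonyl carbon, that is benzoyl to propanoyl. Among the measured compounds shown here, no measured pair in this assay shows exactly that change; the only step that bears on it at all is the one from compound 1 to compound 2, which also alters what is attached to the carbonyl carbon and moved the number by a small amount. On that basis the step from compound 3 to compound 4 is expected to be small, most likely within the scatter, with a slight lean toward a lower number, giving a 1.4-fold lower number from compound 3 to compound 4 (0.15 log units; within the scatter) as the estimated step. Compound 4 is therefore expected to give about 26000 nM in this assay, with a plausible range from 10000 nM to 70000 nM.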

Compound 4, half-maximal inhibitory concentration: 9610 nM
Beside the measured number, compound 4's estimate is 2.7-fold (0.43 log units) above it; measured number outside the range, below it.
By their numbers in this assay, from the lowest: compounds 2, 4 and 1 (each within the scatter of the next, the first and the last beyond it); then compound 3.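

Within the shared core of compound 3 and compound 4, the carbonyl substituent on the amide-type nitrogen affects the result in this assay: ethyl in place of phenyl gives a 3.8-fold lower number from compound 3 to compound 4 (0.58 log units; beyond the scatter). The aromatic ring on this carbonyl carbon is therefore not required for the activity seen in this pair, and removing it lowers the number. The only earlier step, a 2.3-fold lower number from compound 1 to compound 2 (0.36 log units; beyond the scatter), was a change on a saturated chain carbon in a different core, so this is the first reading of a change made directly on the carbonyl carbon, and the data shown offer no measured explanation for the shift.

As far as these compounds go, what remains open is whether the lower number comes from losing the phenyl ring or from the ethyl group itself, which a longer chain such as butyl, a methyl, or a saturated ring such as cyclohexyl on the same carbonyl carbon would help to separate. From the compounds shown here alone, it is also open whether an amine on the propanoyl chain, such as the diallylamino group carried by compound 2, would lower the number further on the core of compound 4.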